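Changing the Amide Acyl Group on a Shared Core

The compounds below may be only part of what the source reports. "The series", "measured", "known", "first", "only" and "open" are said of these compounds alone.

Among the compounds with values here, compound 1 `O=C(Nc1cc(Sc2ncn[nH]2)c(O)c2ccccc12)c1ccc2ccccc2c1` carries the only numerical reading in this set: in a functional assay on MDA-MB-231 cells (Homo sapiens) for antiproliferative activity, read by MTT assay, with a stated time of 48 h (on this read-out lower numbers stand for stronger inhibition and higher numbers for weaker inhibition), compound 1 gives 45100 nM. Compound 2 `Cn1nnnc1Sc1cc(NC(=O)c2ccc(Cl)cc2)c2ccccc2c1O` was measured alongside it, but in this assay compound 2 reports only > 100000 nM, which is a limit of the assay and not a number, so that one of the two readings sits at the limit of > 100000 nM in this assay, at which 1 of the 2 values shown sits. Compound 1 and compound 2 differ in more than one place, and their two values show no more than that one yields a number while the other does not.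

Compound 3 `O=C(/C=C/c1ccc(Cl)cc1)Nc1cc(Sc2ncn[nH]2)c(O)c2ccccc12` differs from compound 1 in a single place: 2-(4-chlorophenyl)ethenyl in place of naphthalen-2-yl on a carbonyl carbon. Within the data shown here, no step between measured compounds is available to calibrate this change, so the direction rests on the structural change alone. Compound 3 is expected to show, in this assay, a step from compound 1 of a 1.3-fold higher number from compound 1 to compound 3 (0.12 log units; within the scatter), a slight loss that may not exceed the scatter. The estimate for compound 3 in this assay is 60000 nM, with a range from 18000 nM to 200000 nM, and a real chance that only a limit is reported.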

Compound 3, half-maximal inhibitory concentration: > 100000 nM
Compound 3 gave a limit, no number; the forecaster's own chance of this, stated with the estimate: 35%; middle value at least 1.6-fold (0.22 log units) away from the limit.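

Within the data shown here, the step shows that the group on the carbonyl carbon is not interchangeable on this core: in this assay, 2-(4-chlorophenyl)ethenyl in place of naphthalen-2-yl gives an at least 2.2-fold higher number from compound 1 to compound 3 (0.34 log units; beyond the scatter), a change that lies beyond the scatter and is the first one-place comparison in the set. Compound 3 reports > 100000 nM, which is a limit of the assay and not a number, so the step fixes a direction and a minimum size but no end point. Among the compounds shown, compound 1 is now the only one with a numerical reading, and the other two share one ceiling: the limit of > 100000 nM in this assay, at which 2 of the 3 values shown sit.

The swap alters several things at once, removing one of the two six-membered aromatic rings, adding a chlorine and adding a double bond outside aromatic rings, so the compounds shown cannot say which of these accounts for the step. From the compounds shown here alone, it also remains open how the reading would respond to other groups on that carbonyl carbon, such as a plain phenyl, a saturated 2-(4-chlorophenyl)ethyl chain, or a naphthalen-2-yl ring carrying a chlorine or an amine.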